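Thiophen-3-yl for thiophen-2-yl in a weak series

A few compounds are considered here, and "the series" means these few. Any claim that something is new, unique, unknown or untested is made for them only; others in the source may bear on it.

In a functional assay on CCRF-CEM cells (Homo sapiens), read by MTT assay, with a stated time of 72 h (a lower number here means a stronger inhibitor, a higher number a weaker inhibitor), compound 1 `Nc1nc2c(c(-c3ccoc3)cn2[C@@H]2O[C@H](CO)[C@@H](O)[C@H]2O)c(=O)[nH]1` gives 17900 nM. Compound 2 `Nc1nc2c(c(-c3cccs3)cn2[C@@H]2O[C@H](CO)[C@@H](O)[C@H]2O)c(=O)[nH]1` gives > 20000 nM, which is a limit of the assay and not a number. Compound 3 `Nc1nc2c(c(-c3ccsc3)cn2[C@@H]2O[C@H](CO)[C@@H](O)[C@H]2O)c(=O)[nH]1` differs from it by one change: thiophen-3-yl in place of thiophen-2-yl on an aromatic carbon. Going by the values given here, the only measured step bearing on this, an at least 1.1-fold higher number from compound 1 to compound 2 (0.04 log units; that floor lies within the scatter), gives no ground to expect a move beyond the scatter in this assay, in either direction. The expected step is an at least 1.1-fold lower number from compound 2 to compound 3 (0.04 log units; that floor lies within the scatter). Compound 3 is estimated at 18000 nM, with an expected range of 8000 nM to 40000 nM.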

Compound 3, half-maximal inhibitory concentration: > 20000 nM
Compound 3 was reported as a limit; the forecaster's own chance of this, stated with the estimate: 55%; at least 1.1-fold (0.04 log units) between middle value and limit.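

Thiophen-3-yl on this aromatic carbon brings no readable value: in this assay compound 3 gives > 20000 nM, which is a limit of the assay and not a number. Thiophen-3-yl in place of furan-3-yl gives an at least 1.1-fold higher number from compound 1 to compound 3 (0.04 log units; that floor lies within the scatter). The step between compound 2 and compound 3 cannot be read, and both thiophene isomers now stop at the same ceiling: the limit of > 20000 nM in this assay, at which 2 of the 3 values shown sit.

Open, as far as these compounds go, is whether an amine or a carboxylic acid on the five-membered ring at this carbon would give a number under that limit. The three rings shown allow no ranking among them.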